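A few compounds are considered here, and "the series" means these few. Any claim that something is new, unique, unknown or untested is made for them only; others in the source may bear on it.

Compound 1 `COc1c(CC=C(C)C)cc([C@@H]2CC(=O)c3ccc(O)cc3O2)cc1CC=C(C)C` — 12000 nM
Compound 2 `COc1c(CC=C(C)C)cc(C2CC(=O)c3ccc(O)cc3O2)cc1CC=C(C)C` — 33000 nM
Compound 3 `CC(C)=CCc1cc([C@H]2CC(=O)c3ccc(O)cc3O2)cc2c1OC(C)(C)C=C2` — 42000 nM

In a functional assay on PC-3M cells (Homo sapiens) for inhibition, read by MTT assay, with a stated time of 3 days (on this read-out higher numbers stand for lower toxicity in this test and lower numbers for higher toxicity in this test), compound 2 gives 33000 nM, the second highest of the three numbers. Its nearest neighbour is compound 3, whose value of 42000 nM lies within the scatter of it. Going by the values given here, the furthest is compound 1, at 12000 nM, and the one step that separates them is a 2.8-fold higher number from compound 1 to compound 2 (0.44 log units; beyond the scatter); what sets the two apart is the fact that one of compounds 1 and 2 is drawn with a defined configuration and the other without, at the place where they differ.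

Compound 4 `COc1c(CC=C(C)C)cc([C@H]2CC(=O)c3ccc(O)cc3O2)cc1CC=C(C)C` has not yet been measured. It differs from compound 2 in this way: the two compounds have the same atoms and bonds; at least one stereo element is drawn with a configuration in one of them and without one in the other: 1 of 1 stereo elements differ; a stereocentre at a saturated ring carbon is drawn without a configuration in compound 2 and R in compound 4. Among the compounds with values here, the only measured step that bears on this change is the one from compound 1 to compound 2, which was modest but beyond the scatter, with the number rising as the drawn configuration was removed. Since compound 4 carries the opposite configuration to compound 1, the expectation is that the number moves further in the same direction, giving a modest rise in this assay beyond the scatter.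

For compound 4 the value in this assay is therefore estimated at 60000 nM, with a range from 25000 nM to 150000 nM. The step from compound 2 that this estimate implies is expected to be a 1.8-fold higher number from compound 2 to compound 4 (0.26 log units; within the scatter).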

Compound 4, half-maximal cytotoxic concentration: 46000 nM
Beside the measured number, compound 4's estimate is 1.3-fold (0.12 log units) above it; the measured number falls inside the stated range.
By their numbers in this assay, from the lowest: compound 1; then compounds 2, 3 and 4 (each within the scatter of the next).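

In this assay, going by these compounds alone, the step of a 3.8-fold higher number from compound 1 to compound 4 (0.58 log units; beyond the scatter) is the first direct comparison of the S and R drawings at this saturated ring carbon, and it lies beyond the scatter. The gap can be tied to this one place because nothing else separates the pair: the fact that compounds 1 and 4 differ only in the configuration as drawn. The step of a 1.4-fold higher number from compound 2 to compound 4 (0.14 log units; within the scatter) stays within the scatter, so the R drawing cannot be told apart from the drawing without a configuration, and among these three compounds only the S drawing of compound 1 stands apart from the other two: the fact that one of compounds 2 and 4 is drawn with a defined configuration and the other without, at the place where they differ.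

The compounds shown do not tell what mixture of S and R lies behind compound 2, so its number cannot be split between the two forms. Nor do they tell whether the gap between the S and R drawings would persist if an amine or a carboxylic acid were carried on the shared core, or whether it would appear at all in a cell line other than this one.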